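Acetyl to dimethylamino on the outer phenyl ring

A few compounds are considered here, and "the series" means these few. Any claim that something is new, unique, unknown or untested is made for them only; others in the source may bear on it.

Among the measured compounds shown here, compound 1 `COc1cc(C)cc(-c2c(-c3ccnc(-c4ccc(C(C)=O)cc4)c3)cnn2CC#N)c1` is one of three compounds measured in a functional assay on LOX IMVI cells (Homo sapiens) for cytotoxicity, read by sulforhodamine B assay, with a stated time of 48 h, tested at 0.001 uM (a higher number here means a weaker effect of the compound at the concentration tested, a lower number a stronger effect), where compound 1 gives 101%. Compound 2 `Cc1cc(O)cc(-c2nn(CC#N)cc2-c2ccnc(-c3ccc(Oc4ccccc4)cc3)c2)c1` gives 100% in this assay, and compound 3 `Cc1cc(O)cc(-c2nn(CC#N)cc2-c2ccnc(-c3ccc(N(C)C)cc3)c2)c1` gives 103%. Compound 1 sits second highest of the three, with compound 2 nearest, a number one point lower, and compound 3 furthest, a number two points higher; all three lie within the scatter of one another, so none can be set apart.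

Compound 4 `COc1cc(C)cc(-c2c(-c3ccnc(-c4ccc(N(C)C)cc4)c3)cnn2CC#N)c1` is not yet measured. It differs from compound 1 by dimethylamino in place of acetyl on an aromatic carbon. For the measured compounds named here, the only measured step that bears on it is a number 3 percentage points higher from compound 2 to compound 3 (within the scatter), where dimethylamino also enters on an aromatic carbon, though there it replaces phenoxy rather than acetyl and the ring on the other side carries hydroxy rather than methoxy. Going by the values given here, that step was within the scatter, and every number so far sits near full activity at this concentration. No step beyond the scatter is therefore expected in this assay; the expected step is no change at the digits printed from compound 1 to compound 4 (within the scatter). Compound 4 is estimated at 101%, with a range from 93% to 109%.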

Compound 4, a percentage reported as activity, at one concentration (the size of the read-out at that concentration, not a potency): 88%
Compound 4: middle estimate off by 13 percentage points, on the high side; the measured number lies below the stated range.
By their numbers in this assay, from the lowest: compound 4; then compounds 2, 1 and 3 (each within the scatter of the next).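

In this assay, among the compounds shown here, the change from 4-acetylphenyl to 4-(dimethylamino)phenyl gives a number 13 percentage points lower from compound 1 to compound 4 (beyond the scatter) and is the first step beyond the scatter, though a modest one. For the compounds shown here, the only earlier step that brought in dimethylamino, a number 3 percentage points higher from compound 2 to compound 3 (within the scatter) and replacing phenoxy, stayed within the scatter, so this place on the outer phenyl ring can now be said to register a change at this single concentration. Nothing available accounts for the step, and no measurement bears on its cause.

Going by these compounds, whether the step follows dimethylamino entering or acetyl leaving stays open, and a primary amine or a carboxylic acid at the same place would help to separate the two. On these data alone, a read-out at one concentration also gives no potency, so the size of the effect across concentrations remains unknown.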